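This account rests on a few compounds, and the source may have more. Where it says the series, first, only, none or still open, it means among the compounds named here.

Measured in a functional assay on HeLa cells (Homo sapiens) for inhibition, read by CCK-8 assay, with a stated time of 72 h; a lower number here means a stronger inhibitor, a higher number a weaker inhibitor:
- compound 1 `O=C(/C=C/c1cccnc1)NCCCCCCc1cccc(S(=O)(=O)Nc2ccccc2)c1` gives 30.4 nM
- compound 2 `Cc1cccc(NS(=O)(=O)c2cccc(CCCCCCNC(=O)/C=C/c3cccnc3)c2)c1` gives 65.8 nM
- compound 3 `O=C(/C=C/c1cccnc1)NCCCCCCc1cccc(S(=O)(=O)Nc2ccc(F)c(Cl)c2)c1` gives 385 nM

Compound 1 holds the lowest number of the three in this assay; the nearest is compound 2 with a 2.2-fold higher number from compound 1 to compound 2 (0.34 log units; beyond the scatter), the furthest compound 3 with a 13-fold higher number from compound 1 to compound 3 (1.10 log units; beyond the scatter). Between the two substituted anilines the step is a 5.9-fold higher number from compound 2 to compound 3 (0.77 log units; beyond the scatter).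

Compound 4 `O=C(/C=C/c1cccnc1)NCCCCCCc1cccc(S(=O)(=O)Nc2ccc(C(F)(F)F)cc2)c1` is the next member. Relative to compound 1 the change is trifluoromethyl in place of hydrogen on an aromatic carbon, on the same aniline ring that carries the changes to compound 2 and compound 3. Both of those steps bear on it, and both run to higher numbers: a modest rise for the methyl in compound 2, a large rise for the 3-chloro-4-fluorophenyl in compound 3. A substituent on this ring is therefore expected to raise the number in this assay again, most likely by an amount between those two steps, i.e. a 4.9-fold higher number from compound 1 to compound 4 (0.69 log units; beyond the scatter). Compound 4 is thus estimated at 150 nM in this assay, with a range from 50 nM to 450 nM.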

Compound 4, half-maximal inhibitory concentration: 1450 nM
Estimate against measurement, compound 4: 9.7-fold (0.99 log units) below; measured number above the stated range.
By their numbers in this assay, from the lowest: compound 1; then compound 2; then compound 3; then compound 4.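

In this assay the trifluoromethyl on the aniline ring, para to a large group, gives a 48-fold higher number from compound 1 to compound 4 (1.68 log units; beyond the scatter) and so marks the largest rise on this ring so far. The rise also exceeds those of the earlier substituted anilines, with a 3.8-fold higher number from compound 3 to compound 4 (0.58 log units; beyond the scatter) and a 22-fold higher number from compound 2 to compound 4 (1.34 log units; beyond the scatter) as the two steps, so the size of the change on this ring is not set by the presence of a substituent alone and depends on which substituted ring is present. Nothing available gives a cause for this rise.

Going by these compounds, whether a single fluorine or a methyl in the place of the trifluoromethyl would stay close to compound 1 remains open. Also open, on these data alone, is how an amine on this ring or a longer chain in the shared core would change the number.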